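A few compounds are considered here, and "the series" means these few. Any claim that something is new, unique, unknown or untested is made for them only; others in the source may bear on it.

Measured so far in a functional assay on CWR22R cells (Homo sapiens) for antiproliferative activity, read by CCK-8 assay, with a stated time of 6 days; on this read-out lower numbers stand for stronger inhibition and higher numbers for weaker inhibition:
Compound 1 `CCN(c1ccc(C#N)c(Cl)c1)c1cc(-c2ccco2)ccc1C`: > 30000 nM (a limit)
Compound 2 `CCN(c1ccc(C#N)c(Cl)c1)c1cc(-c2ccccc2)ccc1C`: > 30000 nM (a limit)
Compound 3 `CCN(c1ccc(C#N)c(Cl)c1)c1cc(-c2ccnn2C)ccc1C`: 4330 nM

Compound 3 is the only one of the three with a number. Compound 1 and compound 2 both sit at the limit of > 30000 nM in this assay, at which 2 of the 3 values shown sit.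

Next is compound 4 `CCN(c1ccc(C#N)c(Cl)c1)c1cc(-c2cccs2)ccc1C`, which carries thiophen-2-yl in place of 1-methyl-1H-pyrazol-5-yl on an aromatic carbon.

Within the data shown here, two measured steps bear on this change: an at least 6.9-fold lower number from compound 1 to compound 3 (0.84 log units; beyond the scatter), and an at least 6.9-fold lower number from compound 2 to compound 3 (0.84 log units; beyond the scatter). Both bring 1-methyl-1H-pyrazol-5-yl in, whereas compound 4 gives it up. The third step, a step that the two limits leave unreadable from compound 1 to compound 2, adds no size. Among the measured compounds, compound 1 with furan-2-yl is the closest match to compound 4 by group name.

Among the measured compounds shown here, a higher number is expected in this assay, beyond the scatter, because an at least 6.9-fold lower number from compound 1 to compound 3 (0.84 log units; beyond the scatter) is the nearest precedent, read in reverse. The expected step is a 4.6-fold higher number from compound 3 to compound 4 (0.66 log units; beyond the scatter). Compound 4 may well return only a limit. For compound 4 the estimated value is 20000 nM, with an expected range of 8000 nM to 40000 nM.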

Compound 4, half-maximal inhibitory concentration: 22000 nM
Compound 4: middle estimate off by 1.1-fold (0.04 log units), on the low side; measured number inside the range.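

In this assay, thiophen-2-yl in place of 1-methyl-1H-pyrazol-5-yl on this aromatic carbon, meta to a large group and para to a methyl group, gives a 5.1-fold higher number from compound 3 to compound 4 (0.71 log units; beyond the scatter). The preference for the pyrazole at this position therefore now rests on two measured numbers and no longer only on comparisons with limits. The comparisons with the other two aryl groups show an at least 1.3-fold lower number from compound 2 to compound 4 (0.13 log units; that floor lies within the scatter) and an at least 1.3-fold lower number from compound 1 to compound 4 (0.13 log units; that floor lies within the scatter), so these floors do not separate thiophen-2-yl from phenyl or furan-2-yl, and both comparisons stop at a limit of the assay: the limit of > 30000 nM in this assay, at which 2 of the 4 values shown sit.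

The change swaps one sulfur for two nitrogens and also removes the methyl group on the pyrazole, so the compounds shown do not tell which of these parts carries the step. Open, going by these compounds, are the pyrazole without its methyl group, a pyridine ring, and a thiophene or pyrazole bearing an amine or a carboxylic acid, as well as how far any of these would move the number below that of compound 3.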